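The source may report more compounds than this note shows. Statements on the series, on what has been measured and on what is new or still open speak of the compounds shown alone.

Working notes on the series. Among the compounds with values here, in a functional assay on A-375 cells (Homo sapiens) for cytotoxicity, read by CCK-8 assay, with a stated time of 24 h (a lower number here means a stronger inhibitor, a higher number a weaker inhibitor), compound 1 (`COc1ccccc1Oc1c(N)nc(-c2ccccc2)nc1Cl`) gives 7220 nM and compound 2 (`COc1ccccc1Oc1c(N)nc(-c2ccc(Cl)cc2)nc1Cl`) gives 1030 nM as the lower of the two numbers so far. The next compound, compound 3 (`COc1ccccc1Oc1c(N)nc(-c2cccc(I)c2)nc1Cl`), has 3-iodophenyl in place of 4-chlorophenyl on an aromatic carbon, while the rest of the structure stays the same.

Within the data shown here, only one measured step bears on this change: a 7.0-fold lower number from compound 1 to compound 2 (0.85 log units; beyond the scatter), a modest step with chloro in place of hydrogen on an aromatic carbon. Among the measured compounds shown here, compound 3 also carries a halogen on that phenyl, but no measured compound has iodo or shows the effect of the 3-iodophenyl arrangement, so that step cannot be transferred directly. A small rise in this assay is expected, with compound 3 remaining closer to compound 2 than to compound 1, and no clear step beyond the scatter. The estimated change is a 1.6-fold higher number from compound 2 to compound 3 (0.19 log units; within the scatter) in this read-out. For compound 3 the estimate is 1600 nM, with an expected range of 500 nM to 5000 nM in the same assay.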

Compound 3, half-maximal inhibitory concentration: 2200 nM
Estimate against measurement, compound 3: 1.4-fold (0.14 log units) below; the measured number falls inside the stated range.
By their numbers in this assay, from the lowest: compound 2; then compound 3; then compound 1.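

In this assay the lower number seen with a halogen on the phenyl group is no longer limited to the chloro of compound 2: a 3.3-fold lower number from compound 1 to compound 3 (0.52 log units; beyond the scatter) shows that iodo in place of hydrogen also lowers the number, though at a different ring position. The two halogenated compounds are not equivalent, as a 2.1-fold higher number from compound 2 to compound 3 (0.33 log units; beyond the scatter) marks a modest loss on going from 4-chlorophenyl to 3-iodophenyl, so compound 2 still has the lowest number of the three and none of the three compounds goes against the halogen trend. No measurement on hand offers an explanation for these differences.

The step from 4-chlorophenyl to 3-iodophenyl alters the halogen and its ring position together, and no pair shown holds one fixed while the other changes, so the share of each in the difference stays open. Also open, going by these compounds, is whether a group of another kind on this phenyl, such as a methoxy group, a nitrile, an amine or a carboxylic acid, would keep the number near that of the halogenated compounds or return it toward that of compound 1.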